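This account rests on a few compounds, and the source may have more. Where it says the series, first, only, none or still open, it means among the compounds named here.

Compound 1 `Cc1ccc(-c2csc(N3N=C(c4ccc(C)s4)CC3c3ccc(F)cc3)n2)cc1` gives > 500 ug/mL in a functional assay on A549 cells (Homo sapiens) for antiproliferative activity, read by XTT assay, with a stated time of 24 h; a lower number here means a stronger inhibitor, a higher number a weaker inhibitor; this value is a limit of the assay, not a number. Compound 2 `Cc1ccc(C2=NN(c3nc(-c4ccc(Br)cc4)cs3)C(c3ccc(F)cc3)C2)s1` gives > 500 ug/mL; this too is a limit of the assay. Compound 3 `Fc1ccc(C2CC(c3ccc(Cl)s3)=NN2c2nc(-c3ccc(Br)cc3)cs2)cc1` gives 62.5 ug/mL.

Among the measured compounds shown here, compound 3 thus stands as the only real number among the three, the other two sitting at the limit of > 500 ug/mL in this assay, at which 2 of the 3 values shown sit. The step that the two limits leave unreadable from compound 1 to compound 2 cannot be read, since both ends are limits. For the measured compounds named here, the step of an at least 8.0-fold lower number from compound 2 to compound 3 (0.90 log units; beyond the scatter) is the one readable change, and it concerns the substituent on the five-membered sulfur ring, not the group on the phenyl ring attached to the core.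

Compound 4 `Fc1ccc(-c2csc(N3N=C(c4ccc(Cl)s4)CC3c3ccc(F)cc3)n2)cc1` is not yet measured. It differs from compound 3 by fluoro in place of bromo on an aromatic carbon. Going by the values given here, none of the measured steps touches this phenyl position, so no measured step bears directly on the change; the only readable step concerns a different ring. Without a guide, the expectation is that the number in this assay stays close to that of compound 3, with no step beyond the scatter. The estimate for compound 4 is therefore 62.5 ug/mL, with a range from 25 ug/mL to 160 ug/mL, which corresponds to an expected step of no change at the digits printed from compound 3 to compound 4 (within the scatter).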

Compound 4, half-maximal inhibitory concentration: > 500 ug/mL
Compound 4: no number, only a limit; the forecaster's own chance of this, stated with the estimate: 20%; at least 8.0-fold (0.90 log units) between middle value and limit.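

Among the compounds shown here, until now this phenyl position could not be judged, since the only earlier step that touched it has a limit at both ends and cannot be read. In this assay, going from 4-bromophenyl to 4-fluorophenyl gives an at least 8.0-fold higher number from compound 3 to compound 4 (0.90 log units; beyond the scatter), so the group on this ring clearly matters, and bromo and fluoro cannot be treated as interchangeable here, even though each is a single halogen atom with no ring, hydrogen-bond donor or acceptor, or charge. Compound 4 keeps the chloro group on the five-membered sulfur ring and still gives > 500 ug/mL, which is a limit of the assay and not a number, so that chloro group alone does not bring a measurable value in this pair.

From the compounds shown here alone, the true size of this step stays unknown, and most of the series offers no number to compare: the limit of > 500 ug/mL in this assay, at which 3 of the 4 values shown sit. Also open is how a chloro, methoxy or amine group on this phenyl ring would compare with bromo and fluoro, and whether any such group would give a lower number than compound 3.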